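The compounds below may be only part of what the source reports. "The series", "measured", "known", "first", "only" and "open" are said of these compounds alone.

Compound 1 `O=C(C1CC1)N1CC2CC1CN2` gives 10000 nM in an assay on CHO cells for displacement of a labelled ligand from Neuronal acetylcholine receptor; alpha3/alpha6/beta2/beta3 (Homo sapiens), read by scintillation counting; on this read-out higher numbers stand for weaker inhibition and lower numbers for stronger inhibition.
Compound 2 `CC(=O)N1CC2CC(C1)N2` gives 610 nM.
Compound 3 `CCC(=O)N1CC2CC(C1)N2` gives 190 nM.

Compound 3 holds the lowest of the three numbers. The nearest is compound 2, reached by the step of a 3.2-fold lower number from compound 2 to compound 3 (0.51 log units; beyond the scatter), which lies beyond the scatter; compound 1, with a different core, gives a far higher number.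

Compound 4 `CCCC(=O)N1CC2CC(C1)N2` differs from compound 3 by methyl in place of hydrogen on a saturated chain carbon, two bonds along the chain from a carbonyl carbon. For the measured compounds named here, the only measured step that bears on this, a 3.2-fold lower number from compound 2 to compound 3 (0.51 log units; beyond the scatter), also lengthened the same chain by one carbon and lowered the number modestly. A second lengthening is expected to lower the number again, if at all, by a smaller amount, a 1.7-fold lower number from compound 3 to compound 4 (0.24 log units; within the scatter), possibly within the scatter. Compound 4 is therefore estimated at 110 nM in this assay, within a range from 40 nM to 350 nM.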

Compound 4, inhibition constant: 350 nM
Compound 4: middle estimate off by 3.2-fold (0.50 log units), on the low side, and the stated range covers the measured number.
By their numbers in this assay, from the lowest: compounds 3, 4 and 2 (each within the scatter of the next, the first and the last beyond it); then compound 1.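

Lengthening the chain once more, ethyl to propyl, gives a 1.8-fold higher number from compound 3 to compound 4 (0.27 log units; within the scatter), so the clear drop seen with the first lengthening does not demonstrably continue. Compound 4 also cannot be separated from the shortest chain, with a 1.7-fold lower number from compound 2 to compound 4 (0.24 log units; within the scatter), although compound 2 and compound 3 do differ beyond the scatter. Nothing shown here offers an explanation for this.

As far as these compounds go, whether a butyl chain, a branched chain or an amine in place of the propyl group would move the number beyond the scatter remains open.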